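Extending the tail of an adenosine receptor ligand with a larger group

This account rests on a few compounds, and the source may have more. Where it says the series, first, only, none or still open, it means among the compounds named here.

Compound 2 `CNC(=O)[C@@]12C[C@@H]1[C@@H](n1cnc3c(NCc4cccc(Cl)c4)nc(C#CCCCCc4cn(CCCCN)nn4)nc31)[C@H](O)[C@@H]2O` was tested in an assay on CHO cells for displacement of a labelled ligand from adenosine receptor A1 (Homo sapiens), read by scintillation counting, tested at 10 uM (a lower number here means less inhibition, a higher number more inhibition at the concentration tested (going by the name of the read-out)), where compound 2 gives 13%. Within the data shown here, the only other measured compound is compound 1 `CNC(=O)[C@@]12C[C@@H]1[C@@H](n1cnc3c(NCc4cccc(Cl)c4)nc(C#CCCCCc4cn(CCNC(C)=O)nn4)nc31)[C@H](O)[C@@H]2O`, which in this assay gives 12%; the step of a number 1 percentage points higher from compound 1 to compound 2 (within the scatter) shows that these two numbers cannot be told apart. Compound 3 `CNC(=O)[C@@]12C[C@@H]1[C@@H](n1cnc3c(NCc4cccc(Cl)c4)nc(C#CCCCCc4cn(Cc5ccc(-n6sccc6=O)cc5)nn4)nc31)[C@H](O)[C@@H]2O` differs from compound 2 by a group of 12 heavy atoms (9 carbon, 1 nitrogen, 1 oxygen, 1 sulfur; one five-membered aromatic ring with 2 hetero atoms, one six-membered aromatic ring of carbon only) in place of a group of 4 heavy atoms (3 carbon, 1 nitrogen; no ring), on a saturated chain carbon bound to an aromatic nitrogen. Among the measured compounds shown here, the single measured step, from compound 1 to compound 2, concerned the same end of the molecule but exchanged two small groups, so it says little about installing a much larger group there. For the measured compounds named here, with the tail position so far showing no movement, the step of a number 2 percentage points higher from compound 2 to compound 3 (within the scatter) is expected to be small, without a direction that can be trusted. Compound 3 is therefore estimated to give 15%, with a range from 4% to 35%.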

Compound 3, a percentage reported as inhibition, at one concentration (the size of the read-out at that concentration, not a potency): 15%
For compound 3 middle estimate and measured number coincide at the digits printed, and the stated range covers the measured number.
By their numbers in this assay, from the lowest: compounds 1, 2 and 3 (each within the scatter of the next).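

In this assay the group with two aromatic rings, on a saturated chain carbon bound to an aromatic nitrogen, gives a number 2 percentage points higher from compound 2 to compound 3 (within the scatter) and a number 3 percentage points higher from compound 1 to compound 3 (within the scatter) when set against the two small groups without a ring. The earlier step only exchanged one small group for another; this one shows that even a group of 12 heavy atoms at this position gives a number that cannot be told apart from those of the small groups, at the one concentration used. No information at hand accounts for this result.

As far as these compounds go, whether a carboxylic acid or a plain benzyl group without the five-membered ring would read differently at this position stays open. So does whether these three compounds would separate at a higher concentration.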